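The source may report more compounds than this note shows. Statements on the series, on what has been measured and on what is new or still open speak of the compounds shown alone.

Compound 1, `CCCc1nc(-c2ccccc2)c(CNCCN2CCN(c3ccccc3Cl)CC2)o1`, gives 60.1%. Compound 2, `CCCc1nc(-c2ccccc2)c(CNCCCN2CCN(c3ccc(F)cc3)CC2)o1`, gives 62.5%. Compound 3, `CCCc1nc(-c2ccccc2)c(CNCCN2CCN(c3cccc(OC)c3)CC2)o1`, gives 40.2%.

These three values come from an assay on HEK293 cells for inhibition of Voltage-dependent T-type calcium channel subunit alpha-1G (Homo sapiens), read by fluorescence, tested at 10 uM; a higher number here means more inhibition at the concentration tested (going by the name of the read-out), a lower number less inhibition. Compound 2 stands highest of the three numbers, but its nearest neighbour, compound 1, sits within the scatter of it, so the two cannot be ordered; only compound 3 lies beyond the scatter below compound 2. Among the measured compounds shown here, the one step between measured compounds that differ in a single place is a number 19.9 percentage points lower from compound 1 to compound 3 (beyond the scatter), a modest drop for 3-methoxyphenyl in place of 2-chlorophenyl on an amine nitrogen in a ring.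

Compound 4, `CCCc1nc(-c2ccccc2)c(CNCCCN2CCN(c3ccc(OC)cc3)CC2)o1`, differs from compound 2 by methoxy in place of fluoro on an aromatic carbon. For the measured compounds named here, no measured pair shows methoxy in place of fluoro on an aromatic carbon, so the step from compound 1 to compound 3 bears on it only loosely: it too brings in a methoxy on the aryl ring of the amine, though at a different place and in exchange for chloro rather than fluoro. On that slender basis a modest decrease in this assay is expected for compound 4, a number 12.5 percentage points lower from compound 2 to compound 4 (beyond the scatter), with a wide range. The estimate for compound 4 is 50%, between 30% and 70%.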

Compound 4, a percentage reported as inhibition, at one concentration (the size of the read-out at that concentration, not a potency): 42.1%
For compound 4 the middle estimate is 7.9 percentage points above the measured one, within the range that was stated.
By their numbers in this assay, from the lowest: compounds 3 and 4 (each within the scatter of the next); then compounds 1 and 2 (each within the scatter of the next).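

In this assay, among the compounds shown here, the change from 4-fluorophenyl to 4-methoxyphenyl gives a number 20.4 percentage points lower from compound 2 to compound 4 (beyond the scatter), the first direct reading of methoxy in place of fluoro on an aromatic carbon para to a large group. The earlier fall, a number 19.9 percentage points lower from compound 1 to compound 3 (beyond the scatter), came with a change of both the group and its place on the ring, so it could not show that this exchange at one fixed place is enough by itself to lower the number beyond the scatter. In both of these single-place steps a methoxy enters and the number falls, with no such pair among the compounds shown going against it, but nothing given here accounts for the fall at this position.

The compounds shown leave open whether a methyl, a hydroxyl or a chloro at this same place would stand with the fluoro or with the methoxy, which would tell whether the fall is particular to methoxy. They also leave open whether 4-fluorophenyl to 4-methoxyphenyl would give a similar step on the amine chain of compound 1, and how the step would look as a potency rather than at a single concentration.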